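A few compounds are considered here, and "the series" means these few. Any claim that something is new, unique, unknown or untested is made for them only; others in the source may bear on it.

Compound 1, `Nc1ccccc1NC(=O)c1ccc(CSC(=S)N2CCN(c3cnccn3)CC2)cc1`, gives 80.5% in a functional assay on MGC-803 cells (Homo sapiens) for antiproliferative activity, read by CCK-8 assay, with a stated time of 72 h, tested at 8 uM; on this read-out lower numbers stand for a weaker effect and higher numbers for a stronger effect at the one concentration tested.
Compound 2, `CN1CCN(C(=S)SCc2ccc(C(=O)Nc3ccccc3N)cc2)CC1`, gives 84.4% in this assay.

Of the two numbers shown in this assay, the one for compound 2 is the larger, but the margin to compound 1 lies within the scatter, so the two compounds cannot be separated. Among the compounds with values here, the single measured step, a number 3.9 percentage points higher from compound 1 to compound 2 (within the scatter), is the only comparison available. Compound 3, `N#Cc1ccc(N2CCN(C(=S)SCc3ccc(C(=O)Nc4ccccc4N)cc3)CC2)cc1`, has not yet been measured in this assay. It differs from compound 2 in one place: 4-cyanophenyl in place of methyl on an amine nitrogen in a ring. The step from compound 1 to compound 2 bears on this, since it also swapped a ring group for methyl on the same amine nitrogen in a ring, and it moved the read-out by a number 3.9 percentage points higher from compound 1 to compound 2 (within the scatter). Compound 3 reverses that kind of exchange, putting a ring group back in place of methyl. Within the data shown here, since no measured step goes beyond the scatter, no step beyond the scatter is expected here, and the shift in a number 4.4 percentage points lower from compound 2 to compound 3 (within the scatter) is expected to be small. Compound 3 is therefore estimated at 80%, with a range from 65% to 92%.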

Compound 3, a percentage reported as inhibition, at one concentration (the size of the read-out at that concentration, not a potency): 37.6%
The estimate for compound 3 lay 42.4 percentage points above the measured number; measured number outside the range, below it.
By their numbers in this assay, from the lowest: compound 3; then compounds 1 and 2 (each within the scatter of the next).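

This result shows that the amine nitrogen in the six-membered non-aromatic ring is not indifferent to what it carries: in this assay, 4-cyanophenyl in place of methyl gives a number 46.8 percentage points lower from compound 2 to compound 3 (beyond the scatter) and so takes the read-out well away from the level the earlier pair shared. A ring on this nitrogen does not bring such a loss in every case, since compound 1 with pyrazin-2-yl and compound 2 with methyl could not be separated, whereas 4-cyanophenyl in place of pyrazin-2-yl gives a number 42.9 percentage points lower from compound 1 to compound 3 (beyond the scatter) on the same shared core, so the two ring groups are not interchangeable here. Nothing at hand gives a measured reason for this loss of effect at the one concentration tested.

The compounds shown leave open whether the drop belongs to the nitrile or to the carbon-only aromatic ring that carries it, a question that a plain phenyl group on the same nitrogen would address. They also leave open how a benzyl group, an ethyl group or a 4-methoxyphenyl group at this place would stand in this assay against these three compounds.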